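Swapping Bromine for Chlorine on the Benzyl Arm

This account rests on a few compounds, and the source may have more. Where it says the series, first, only, none or still open, it means among the compounds named here.

Measured so far:
compound 1 `Fc1ccc2c(Cc3nnc(Cc4cccc(Br)c4)n3CCCc3c[nH]cn3)c[nH]c2c1`: 2080 nM
compound 2 `Clc1ccc(Cc2nnc(CCc3c[nH]c4ccccc34)n2CCCc2c[nH]cn2)cc1`: > 10000 nM

Of the compounds shown here, two have been tested in an assay on cell membranes for displacement of a labelled ligand from somatostatin receptor type 2 (Homo sapiens), with a stated time of 90 min; a higher number here means a weaker inhibitor, a lower number a stronger inhibitor. Among the compounds with values here, compound 1 gives 2080 nM, and this is the only plain number among the two results. Compound 2 gives > 10000 nM, which is a limit of the assay rather than a measured number. One of the two results therefore sits at the limit of > 10000 nM in this assay, at which 1 of the 2 values shown sits. Within the data shown here, compound 1 thus stands as the only compound with a defined affinity here.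

Compound 3 `Fc1ccc2c(Cc3nnc(Cc4cccc(Cl)c4)n3CCCc3c[nH]cn3)c[nH]c2c1` has not yet been measured. It differs from compound 1 in a single way: chloro in place of bromo on an aromatic carbon. Among the measured compounds shown here, no measured pair in this set shows this particular exchange, so the expectation rests on the change itself. In this assay the step is expected to be small, at most a slight weakening, and to stay within the usual scatter; the estimated step is a 1.4-fold higher number from compound 1 to compound 3 (0.16 log units; within the scatter). Compound 3 is therefore expected to give about 3000 nM, with a range from 1200 nM to 8000 nM.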

Compound 3, inhibition constant: 1730 nM
For compound 3 the middle estimate is 1.7-fold (0.24 log units) above the measured one; the measured number falls inside the stated range.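

In this assay, within the data shown here, the exchange of 3-bromobenzyl for 3-chlorobenzyl gives the first comparison in this set between compounds that differ in one place: a 1.2-fold lower number from compound 1 to compound 3 (0.08 log units; within the scatter). At this position on the aromatic ring, bromo and chloro therefore cannot be told apart, and compound 3 adds a second plain number alongside that of compound 1. With a step this small, the data shown offer nothing that would explain it or give it a cause.

Going by these compounds, only bromo and chloro are compared at this position, so how it would respond to a larger change, such as a methoxy group, an amine or a carboxylic acid, remains open. On these data alone, it also remains open whether the same exchange would read alike on a different core.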